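Ethyl Versus Methyl on the Thiophene Ring

A few compounds are considered here, and "the series" means these few. Any claim that something is new, unique, unknown or untested is made for them only; others in the source may bear on it.

Compound 1, `CCc1ccc(S(=O)(=O)NC(=O)Nc2ccc(Cl)cc2)s1`: 89%
Compound 2, `CCc1csc(S(=O)(=O)NC(=O)Nc2ccc(Cl)cc2)c1`: 93%
Compound 3, `Cc1cc(S(=O)(=O)NC(=O)Nc2ccc(Cl)cc2)sc1C`: 73%

Three sulfonylureas sharing the same chlorophenyl urea core were measured in a functional assay on the whole organism (6C3HED cells, Mus musculus) for inhibition, at a dose of 300 mg/kg by the oral route; on this read-out lower numbers stand for less inhibition and higher numbers for more inhibition at the one dose given (going by the name of the read-out). Compound 1 gives 89%, compound 2 gives 93%, and compound 3, with a 4,5-dimethylthiophen-2-yl on the sulfonyl sulfur, gives 73%, the lowest of the three. The steps of a number 16 percentage points lower from compound 1 to compound 3 (beyond the scatter) and a number 20 percentage points lower from compound 2 to compound 3 (beyond the scatter) both lie beyond the scatter, while a number 4 percentage points higher from compound 1 to compound 2 (within the scatter) lies within it.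

Compound 4, `CCc1sc(S(=O)(=O)NC(=O)Nc2ccc(Cl)cc2)cc1C`, has not yet been measured in this assay. It differs from compound 3 by a single change: methyl in place of hydrogen on a saturated chain carbon bound to an aromatic carbon.

This change bears on the step from compound 1 to compound 3, since compound 4 carries the 5-ethyl group of compound 1 together with the extra methyl of compound 3. Because a number 16 percentage points lower from compound 1 to compound 3 (beyond the scatter) was a modest fall when the ethyl was traded for the dimethyl pattern, restoring an ethyl chain in compound 4 is expected to recover part of that ground. A modest rise, a number 9 percentage points higher from compound 3 to compound 4 (within the scatter), is therefore expected, though the retained methyl leaves uncertainty. Compound 4 is estimated at 82%, within a range from 68% to 94%.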

Compound 4, a percentage reported as inhibition, in the whole organism at one dose (the size of the read-out at that dose, not a potency): 58%
Compound 4: the middle estimate sits 24 percentage points above what was measured, and the stated range ends above it.
By their numbers in this assay, from the lowest: compound 4; then compound 3; then compounds 1 and 2 (each within the scatter of the next).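

Methyl in place of hydrogen on a saturated chain carbon bound to an aromatic carbon, which turns the methyl of compound 3 into an ethyl, gives in this assay a number 15 percentage points lower from compound 3 to compound 4 (beyond the scatter), so this longer chain does not restore the higher numbers here. Methyl in place of hydrogen on an aromatic carbon gives a number 31 percentage points lower from compound 1 to compound 4 (beyond the scatter), which shows that the ethyl group does not on its own secure a high number in this assay: the result also depends on what else the ring carries, something the earlier compounds could not show. Nothing among the data given explains why either change lowers the number, and no independent measurement bears on it.

The compounds shown leave open whether a longer chain such as propyl on that saturated chain carbon would lower the number further or reverse the trend. They also leave open whether a methoxy group in place of the added methyl on the aromatic carbon would give a similar fall, or whether the fall is particular to methyl.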